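This account rests on a few compounds, and the source may have more. Where it says the series, first, only, none or still open, it means among the compounds named here.

Measured compounds:
- compound 1 `CCC(=O)Nc1ccc(S(=O)(=O)c2ccc(N)cc2)cc1` gives 23.5%
- compound 2 `CCCC(=O)Nc1ccc(S(=O)(=O)c2ccc(NC(=O)CCC)cc2)cc1` gives 14.7%

Both numbers come from an assay on isolated protein for inhibition of protein arginine N-methyltransferase 1 (Homo sapiens), read by ELISA, tested at 10 uM; on this read-out higher numbers stand for a stronger effect at the one concentration tested and lower numbers for a weaker effect. Compound 1 and compound 2 lie within the usual scatter of each other, so neither stands apart. Compound 3 `Nc1ccc(S(=O)(=O)c2ccc(NC(=O)NCc3ccccc3)cc2)cc1` has not yet been measured. Relative to compound 1 it shows (benzylamino in place of ethyl on a carbonyl carbon). Among the measured compounds shown here, no measured pair shows a change of this kind, so nothing in the data says how large a step to expect. Without such a precedent, the step is expected to stay within the scatter, giving a number 3.5 percentage points lower from compound 1 to compound 3 (within the scatter) in this assay. Compound 3 is therefore estimated at 20%, likely between 5% and 40%.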

Compound 3, a percentage reported as inhibition, at one concentration (the size of the read-out at that concentration, not a potency): < 5%
Compound 3 was reported as a limit; the forecaster's own chance of this, stated with the estimate: 0%; middle value at least 15 percentage points away from the limit.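

In this assay, putting benzylamino in place of ethyl on a carbonyl carbon gives a number at least 18.5 percentage points lower from compound 1 to compound 3 (beyond the scatter). Compound 3 gives < 5%, which is a limit of the assay and not a number. Among the compounds shown here, this is the first sign that the group on this carbonyl carbon can matter, and that this larger group is not tolerated as well as ethyl.

From the compounds shown here alone, it remains open whether the ring or the added nitrogen drives the drop. A benzyl group or a methylamino group on the same carbonyl carbon would separate the two.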